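Swapping the isoxazole for a 2-chloro-6-fluorophenyl amide

The source may hold more compounds than are shown below. What is called first, only, known or untested is meant among the compounds shown, and "the series" means these compounds.

Measured so far:
Compound 1 `O=C(Nc1ccc(Cl)c(-c2nnc3c(Cl)cccn23)c1)c1ccc(F)cc1Cl` in a functional assay on HeLa cells (Homo sapiens) for antiproliferative activity, read by MTT assay, with a stated time of 72 h (on this read-out higher numbers stand for weaker inhibition and lower numbers for stronger inhibition), gives > 100000 nM, which is a limit of the assay and not a number.
Compound 2 `O=C(Nc1ccc(Cl)c(-c2nnc3c(Cl)cccn23)c1)c1ccon1` in this assay gives > 100000 nM, again only a limit.

Compound 2 thus stands at the limit, where both measured values sit (the limit of > 100000 nM in this assay, at which 2 of the 2 values shown sit). Compound 3 `O=C(Nc1ccc(Cl)c(-c2nnc3c(Cl)cccn23)c1)c1c(F)cccc1Cl` differs from compound 2 by 2-chloro-6-fluorophenyl in place of 1,2-oxazol-3-yl on a carbonyl carbon. Going by the values given here, the single measured step, a step that the two limits leave unreadable from compound 1 to compound 2, joins two limits, so its size cannot be read. Compound 3 carries the same atoms as compound 1 in another arrangement. Compound 1 also stands at the limit. Among the compounds with values here, no measured step shows a change beyond the scatter, so none is expected. Compound 3 is estimated at 100000 nM, between 30000 nM and 300000 nM, an expected step of a number no higher from compound 2 to compound 3 (the limit leaves the size open).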

Compound 3, half-maximal inhibitory concentration: > 100000 nM
Compound 3: a limit, no number (the forecaster's own chance of this, stated with the estimate: 85%); the middle value sits exactly at the limit.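

No step can be read among compound 1, compound 2 and compound 3, as all three values are limits and not numbers: the limit of > 100000 nM in this assay, at which 3 of the 3 values shown sit.

Going by these compounds, whether any of these three groups on the carbonyl carbon changes activity on these cells stays open.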